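Amide to urea on the azetidine core: what to expect

The compounds below may be only part of what the source reports. "The series", "measured", "known", "first", "only" and "open" are said of these compounds alone.

Measured compounds:
Compound 1, `CC1CCCC(C(=O)N2CC(c3nc(-c4cccc(Cl)c4)no3)C2)C1`, gives > 10000 nM.
Compound 2, `O=S(=O)(c1ccc(F)cc1)N1CC(c2nc(-c3cccc(Cl)c3)no2)C1`, gives 130 nM.

Both compounds were tested in an assay on HEK293 cells for negative allosteric modulation of metabotropic glutamate receptor 5 (Homo sapiens), read by FLIPR; a higher number here means a weaker inhibitor, a lower number a stronger inhibitor. For compound 1 the value is a limit of the assay, not a number: compound 1 sits at the limit of > 10000 nM in this assay, at which 1 of the 2 values shown sits. Compound 2, in this assay, gives 130 nM, so of the two compounds only compound 2 shows a measurable inhibition.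

Compound 3, `CC1CCN(C(=O)N2CC(c3nc(-c4cccc(Cl)c4)no3)C2)C1`, has not yet been measured in this assay. It differs from compound 1 in one place: 3-methylpyrrolidin-1-yl in place of 3-methylcyclohexyl on a carbonyl carbon. The change turns the amide of compound 1 into a urea while keeping a methyl-bearing saturated ring beside the carbonyl.

Going by the values given here, no measured pair shows what this change does, so the expectation rests only on where compound 1 stands. Compound 1 is expected to remain weak after the change, with the step from compound 1 to compound 3 expected to be an at least 1.2-fold lower number from compound 1 to compound 3 (0.09 log units; that floor lies within the scatter), that is none beyond the scatter. Compound 3 is therefore expected to give about 8000 nM in this assay, within a range of 1500 nM to 30000 nM, and the assay may again report only a limit.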

Compound 3, half-maximal inhibitory concentration: > 10000 nM
Compound 3: a limit, no number (the forecaster's own chance of this, stated with the estimate: 55%); middle value at least 1.2-fold (0.09 log units) away from the limit.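

Compound 1 and compound 3 each return a limit of the assay rather than a number, so no step can be read between them: the limit of > 10000 nM in this assay, at which 2 of the 3 values shown sit.

The compounds shown leave open whether 3-methylpyrrolidin-1-yl and 3-methylcyclohexyl on that carbonyl carbon differ at all in their effect on inhibition.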